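Fluoro to methoxy on the pendant aryl of compound 1

This account rests on a few compounds, and the source may have more. Where it says the series, first, only, none or still open, it means among the compounds named here.

Among the compounds with values here, compound 1 `C=C(Br)C(=O)Nc1cccc(-c2cn3nc(-c4ccc(F)cc4)sc3n2)c1` is the stronger of the two measured members: in a functional assay on FM3A cells (Mus musculus) for inhibition, read by cell counting, with a stated time of 2 days (a lower number here means a stronger inhibitor, a higher number a weaker inhibitor), compound 1 gives 610 nM, while compound 2 `COc1ccc(-c2csc3nc(-c4cccc(N)c4)cn23)cc1` gives 11000 nM in this assay, a gap beyond the usual scatter. Compound 3 `C=C(Br)C(=O)Nc1cccc(-c2cn3nc(-c4ccc(OC)cc4)sc3n2)c1` is not yet measured. Its difference from compound 1 is methoxy in place of fluoro on an aromatic carbon, read one bond further out as 4-fluorophenyl to 4-methoxyphenyl. Within the data shown here, no measured pair isolates this change, so the expected step from compound 1 to compound 3 in this assay is small, a 1.5-fold higher number from compound 1 to compound 3 (0.17 log units; within the scatter), likely within the scatter. Compound 3 is estimated at 900 nM, with a range from 300 nM to 3000 nM.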

Compound 3, half-maximal inhibitory concentration: 890 nM
Compound 3: the middle estimate sits 1.0-fold (0.00 log units) above what was measured, within the range that was stated.
By their numbers in this assay, from the lowest: compounds 1 and 3 (each within the scatter of the next); then compound 2.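

In this assay, within the data shown here, methoxy in place of fluoro, on an aromatic carbon para to a large group, gives a 1.5-fold higher number from compound 1 to compound 3 (0.16 log units; within the scatter) and so provides the first single-place comparison. The position therefore accepts 4-methoxyphenyl as well as 4-fluorophenyl, with no separation between the two in this read-out. No measurement available here bears on the reason for this. From the compounds shown here alone, whether an amine, a carboxylic acid or a longer chain at this position fits the same pattern remains open. Compound 2 differs from compound 3 in more than one place, leaving its higher number unassigned to any single change.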